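This account rests on a few compounds, and the source may have more. Where it says the series, first, only, none or still open, it means among the compounds named here.

The compounds here share one core and differ only in the group at its far end. Compound 1 `CC(C)[C@H](NC(=O)COc1cccc2ccccc12)C(=O)N[C@@H](CC(=O)O)C(=O)COc1ccccc1F` carries a 2-fluorophenoxy group there. In a functional assay on Jurkat cells (Homo sapiens) (a lower number here means a stronger inhibitor, a higher number a weaker inhibitor), compound 1 gives only a limit, > 100000 nM, rather than a measured number. Compound 2 `CC(C)[C@H](NC(=O)COc1cccc2ccccc12)C(=O)N[C@@H](CC(=O)O)C(=O)COc1c(F)c(F)c(-c2c(F)c(F)c(F)c(F)c2F)c(F)c1F` carries a larger and much more heavily fluorinated group in the same place, and in this assay compound 2 gives 20000 nM. Compound 3 `CC(C)[C@H](NC(=O)COc1cccc2ccccc12)C(=O)N[C@@H](CC(=O)O)C(=O)COc1cccc(C(F)(F)F)c1F` differs from compound 1 in a single place: trifluoromethyl in place of hydrogen on an aromatic carbon. Among the compounds with values here, no measured pair of compounds shows exactly this change, so its effect can only be judged from the fact that compound 1 sits at the limit of > 100000 nM in this assay, at which 1 of the 2 values shown sits, while compound 2, with its larger fluorinated group, does reach a number. A modest gain in potency, beyond the usual scatter, is therefore expected for compound 3 in this assay, roughly an at least 1.6-fold lower number from compound 1 to compound 3 (0.22 log units; that floor lies within the scatter), though a limit again cannot be ruled out. For compound 3 the estimate in this assay is 60000 nM, with a range from 15000 nM to 200000 nM.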

Compound 3, half-maximal inhibitory concentration: 50400 nM
Estimate against measurement, compound 3: 1.2-fold (0.08 log units) above, within the range that was stated.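

On the 2-fluorophenoxy group, trifluoromethyl in place of hydrogen gives a compound that reaches a measured number in this assay, which compound 1 does not: compound 3 gives 50400 nM. The change reads as an at least 1.9-fold lower number from compound 1 to compound 3 (0.29 log units; that floor lies within the scatter), so this floor alone does not establish a gain beyond the usual scatter, although the real step may be larger. The step can be bounded from one side only, because compound 1 has a limit and not a number: the limit of > 100000 nM in this assay, at which 1 of the 3 values shown sits.

The compounds shown leave open whether this result belongs to trifluoromethyl itself or would also come with a methyl group, a chlorine atom or a methoxy group on the same aromatic carbon, and whether an amine or a carboxylic acid there would move the number the other way. They also leave open what part the neighbouring fluoro group plays, which a 3-(trifluoromethyl)phenoxy group, with hydrogen in place of that fluoro group, could help to show.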